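The source may hold more compounds than are shown below. What is called first, only, known or untested is meant among the compounds shown, and "the series" means these compounds.

Compound 2 `NC(=O)c1cc(Br)ccc1NC(=O)/C=C/c1ccc(Cl)cc1` stands lowest of the two compounds measured in a functional assay on K562 cells (Homo sapiens) for antiproliferative activity, read by trypan blue exclusion, with a stated time of 48 h, tested at 10 uM; on this read-out higher numbers stand for more inhibition of growth at the one concentration tested and lower numbers for less inhibition of growth; in it compound 2 gives 22%. Within the data shown here, its only neighbour, compound 1 `Cc1ccccc1/C=C/C(=O)Nc1ccc(Cl)cc1C(N)=O`, differs in more than one place, and in this assay compound 1 gives 52.2%, a gap beyond the usual scatter. Compound 3 `Cc1ccccc1/C=C/C(=O)Nc1ccc(Br)cc1C(N)=O` changes compound 2 by 2-methylphenyl in place of 4-chlorophenyl on a double-bonded chain carbon bound to a double-bonded chain carbon. Among the measured compounds shown here, no single-change step among the measured compounds sizes this change, but compound 1 carries the same 2-methylphenyl and gives 52.2%, which points upward. The expected step is a number 23 percentage points higher from compound 2 to compound 3 (beyond the scatter), upward and beyond the scatter. Compound 3 is therefore estimated at 45%, within a range from 25% to 65%.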

Compound 3, percent growth inhibition at one concentration: 43.2%
Compound 3: middle estimate off by 1.8 percentage points, on the high side; the range from low to high includes it.
By their numbers in this assay, from the lowest: compound 2; then compounds 3 and 1 (each within the scatter of the next).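

In this assay the change to 2-methylphenyl in place of 4-chlorophenyl, with the bromo kept, gives a number 21.2 percentage points higher from compound 2 to compound 3 (beyond the scatter) as a single-change step. Bromo in place of chloro on an aromatic carbon, with the 2-methylphenyl kept, gives a number 9 percentage points lower from compound 1 to compound 3 (within the scatter) and so does not separate from the scatter. No measurement here gives a reason for either step. The compounds shown leave open whether the first step follows from the methyl group or from where the group sits on the ring, and whether a phenyl carrying an amine or a carboxylic acid would stand with compound 2 or compound 3.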